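This account rests on a few compounds, and the source may have more. Where it says the series, first, only, none or still open, it means among the compounds named here.

Of the compounds shown here, two have so far been measured in an assay for inhibition of LL-diaminopimelate aminotransferase, chloroplastic (Arabidopsis thaliana); a higher number here means a weaker inhibitor, a lower number a stronger inhibitor. Compound 1 `CCN1C(=O)/C(=C/c2ccc(OC)cc2)SC1=S` carries an ethyl group on an amide-type nitrogen in a ring of its core. In this assay compound 1 gives > 200000 nM, which is a limit of the assay rather than a number. Compound 1 thus stands at the limit of > 200000 nM in this assay, at which 1 of the 2 values shown sits, so only a boundary and no exact figure is known for it. Compound 2 `CC(=O)/N=C1\NC(=O)/C(=C/c2ccc(-c3ccc([N+](=O)[O-])cc3)o2)S1` has a different core and a different aromatic part; in this assay compound 2 gives 78000 nM. Compound 3 `COc1ccc(/C=C2\SC(=S)N(NC(C)=O)C2=O)cc1` differs from compound 1 in one place: acetamido in place of ethyl on an amide-type nitrogen in a ring. Among the compounds with values here, no measured pair of compounds shows what this particular change does, so nothing beyond the two values above guides the expectation. Because compound 1 sits at the limit of > 200000 nM in this assay, at which 1 of the 2 values shown sits, the step is expected to stay within the usual scatter, and an at least 1.3-fold lower number from compound 1 to compound 3 (0.12 log units; that floor lies within the scatter) is therefore an estimate of little or no change. Compound 3 is expected to give about 150000 nM in this assay, within a range from 50000 nM to 400000 nM, and the assay may again report only a limit.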

Compound 3, half-maximal inhibitory concentration: > 200000 nM
Compound 3 ended at the assay's limit (the forecaster's own chance of this, stated with the estimate: 55%); middle value at least 1.3-fold (0.12 log units) away from the limit.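

In this assay compound 3 gives > 200000 nM, which is a limit of the assay and not a number. Within the data shown here, compound 1 also sits at a limit, so no step from compound 1 to compound 3 can be read: the limit of > 200000 nM in this assay, at which 2 of the 3 values shown sit. The compounds shown leave open whether acetamido in place of ethyl changes the inhibition at all, and by how much.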